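Working notes: the step from compound 2 to compound 3

The source may hold more compounds than are shown below. What is called first, only, known or untested is meant among the compounds shown, and "the series" means these compounds.

Measured in an ADME assay on L6 cells (Rattus norvegicus) for cytotoxicity; a lower number here means a stronger inhibitor, a higher number a weaker inhibitor:
- compound 1 `O=C(Cn1cnc([N+](=O)[O-])n1)N1CCN(c2ccccn2)CC1`: 173000 nM
- compound 2 `O=C(Cn1cnc([N+](=O)[O-])n1)N1CCN(c2ccc(Cl)c(Cl)c2)CC1`: 108000 nM

Compound 2 stands within the scatter of compound 1, so these two numbers give no order. Compound 3 `O=C(Cn1cnc([N+](=O)[O-])n1)N1CCN(c2ncccn2)CC1` is not yet measured. The change is pyrimidin-2-yl in place of 3,4-dichlorophenyl on an amine nitrogen in a ring. Within the data shown here, the one measured step that bears on it, 3,4-dichlorophenyl in place of pyridin-2-yl, is a 1.6-fold lower number from compound 1 to compound 2 (0.20 log units; within the scatter). No step beyond the scatter is therefore expected in this assay, and any small move would be toward a higher number, near compound 1 at 173000 nM. The estimated step is a 1.6-fold higher number from compound 2 to compound 3 (0.20 log units; within the scatter). For compound 3 the expected value is 170000 nM, with an estimated range of 90000 nM to 300000 nM.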

Compound 3, half-maximal inhibitory concentration: 150000 nM
The estimate for compound 3 lay 1.1-fold (0.05 log units) above the measured number; the range from low to high includes it.
By their numbers in this assay, from the lowest: compounds 2, 3 and 1 (each within the scatter of the next).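

The step of a 1.4-fold higher number from compound 2 to compound 3 (0.14 log units; within the scatter) and the step of a 1.2-fold lower number from compound 1 to compound 3 (0.06 log units; within the scatter) in this assay both lie within the scatter, so three aromatic groups on this amine nitrogen in a ring now give no order. Pyrimidin-2-yl brings two hydrogen-bond acceptors where 3,4-dichlorophenyl has none, yet the number does not leave the scatter. Nothing on hand gives a reason for this. From the compounds shown here alone, whether an alkyl chain or a carboxylic acid at this position would move the number beyond the scatter remains open.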